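Phenyl for Ethyl on the Saturated Ring Carbon

This account rests on a few compounds, and the source may have more. Where it says the series, first, only, none or still open, it means among the compounds named here.

Measured so far:
compound 1, `Fc1cc2c(cc1OCCCCN1CCN(c3ccccc3)CC1)CCC2`, 79%
compound 2, `O=[N+]([O-])c1cc2c(cc1OCCCN1CCN(c3ccccc3)CC1)CCC2`, 24%
compound 3, `CCC1CCc2ccc(OCCCN3CCN(c4ccc(F)cc4)CC3)cc21`, 44%

Three compounds of this series have been run in a functional assay on the whole organism for inhibition, with Mus musculus as the target, at a dose of 25 mg/kg by the oral route; a lower number here means less inhibition, a higher number more inhibition at the dose given (going by the name of the read-out). Compound 1 `Fc1cc2c(cc1OCCCCN1CCN(c3ccccc3)CC1)CCC2` gives 79%, compound 2 `O=[N+]([O-])c1cc2c(cc1OCCCN1CCN(c3ccccc3)CC1)CCC2` gives 24%, and compound 3 `CCC1CCc2ccc(OCCCN3CCN(c4ccc(F)cc4)CC3)cc21` gives 44%. Among these three numbers compound 3 stands second highest: its nearest neighbour is compound 2, whose number is lower by a margin beyond the scatter, and the furthest is compound 1, whose number is higher by a margin also beyond the scatter. No two of the measured compounds differ in only one place, so no single change has a measured step attached to it.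

Compound 4 `Fc1ccc(N2CCN(CCCOc3ccc4c(c3)C(c3ccccc3)CC4)CC2)cc1` has not yet been measured. It differs from compound 3 in one place: phenyl in place of ethyl on a saturated ring carbon. For the measured compounds named here, no measured pair shows what this exchange does in this assay, so the expected size and direction rest on nothing firmer than the spread of the three numbers in hand. The step from compound 3 to compound 4 is expected to be small, a number 1 percentage points higher from compound 3 to compound 4 (within the scatter), and may well lie within the scatter in either direction. For compound 4 the estimate is 45%, with a range from 15% to 75%.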

Compound 4, a percentage reported as inhibition, in the whole organism at one dose (the size of the read-out at that dose, not a potency): 32%
Estimate against measurement, compound 4: 13 percentage points above; measured number inside the range.
By their numbers in this assay, from the lowest: compounds 2 and 4 (each within the scatter of the next); then compound 3; then compound 1.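

Phenyl in place of ethyl on a saturated ring carbon gives the only single-place step of the series in this assay, a number 12 percentage points lower from compound 3 to compound 4 (beyond the scatter), so the group on this ring carbon does register in the read-out. Over this one pair, the entering phenyl, with its six carbons against the two of ethyl, brings no gain in inhibition at the dose given, and the step holds only for this pair. Nothing at hand gives a reason for this step.

Going by these compounds, whether hydrogen, methyl, hydroxyl or an amine on the same ring carbon would give a number nearer to that of compound 3 or of compound 4 stays open. Compound 1 and compound 2 differ from both in more than one place, so their steps cannot be read.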